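Compound 3 to compound 4: a limit and a ring swap

This account rests on a few compounds, and the source may have more. Where it says the series, first, only, none or still open, it means among the compounds named here.

In an ADME assay on HepG2 cells (Homo sapiens) for cytotoxicity, read by CellTiter-Glo and ATP content, with a stated time of 72 h (a lower number here means that less compound is needed, a higher number that more compound is needed for the effect), compound 1 `CS(=O)(=O)c1ccc(C(=O)NCC(=O)N(Cc2ccccc2)Cc2ccccc2)cc1[N+](=O)[O-]` gives 11900 nM, and compound 2 `CS(=O)(=O)c1ccc(C(=O)NCC(=O)N2CCCCC2)cc1[N+](=O)[O-]` gives 14000 nM. Compound 3 `CN(Cc1ccccc1)C(=O)CNC(=O)c1ccc(S(C)(=O)=O)c([N+](=O)[O-])c1` gives > 27000 nM, which is a limit of the assay and not a number. Compound 3 is the only one of the three at the limit of > 27000 nM in this assay, at which 1 of the 3 values shown sits.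

The next structure is compound 4 `CN1CCN(C(=O)CNC(=O)c2ccc(S(C)(=O)=O)c([N+](=O)[O-])c2)CC1`, with 4-methylpiperazin-1-yl in place of benzyl(methyl)amino on a carbonyl carbon.

The measured step that changes this same place is an at least 1.9-fold higher number from compound 2 to compound 3 (0.28 log units; that floor lies within the scatter). Its floor lies within the scatter. The other step, an at least 2.2-fold higher number from compound 1 to compound 3 (0.35 log units; beyond the scatter), is at least modest, but it has hydrogen in place of phenyl and so changes the group less directly. Compound 2, with its piperidin-1-yl group, gives 14000 nM, so a ring on the carbonyl carbon does not rule out a measurable number. No step beyond the scatter is expected in this assay, and no direction is favoured. The expected step is an at least 1.0-fold lower number from compound 3 to compound 4 (0.01 log units; that floor lies within the scatter). Compound 4 is estimated at 26000 nM, with an expected range of 12000 nM to 55000 nM.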

Compound 4, half-maximal effective concentration: > 27000 nM
Compound 4: no number, only a limit; the forecaster's own chance of this, stated with the estimate: 55%; middle value at least 1.0-fold (0.01 log units) away from the limit.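

In this assay compound 4 gives > 27000 nM, which is a limit of the assay and not a number. The step between compound 3 and compound 4 cannot be read, while the readable new step is an at least 1.9-fold higher number from compound 2 to compound 4 (0.28 log units; that floor lies within the scatter) and its floor gives no change beyond the scatter. New at this place on the carbonyl carbon is that 4-methylpiperazin-1-yl, a non-aromatic ring with 2 hetero atoms, stands at the same limit as benzyl(methyl)amino, which carries an aromatic ring of carbon only: the limit of > 27000 nM in this assay, at which 2 of the 4 values shown sit.

From the compounds shown here alone, how far compound 3 and compound 4 lie past the limit stays open, and so does any order between them. Also open, going by these compounds, is how dimethylamino or morpholin-4-yl on the same carbonyl carbon would read in this assay, and whether either would give a number or the same limit.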